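The source may hold more compounds than are shown below. What is called first, only, known or untested is meant among the compounds shown, and "the series" means these compounds.

Going by the values given here, compound 2, `COc1ccc(F)cc1CNCCCNc1ccnc2cc(Cc3ccc(F)cc3)ccc12`, gives 23 10^-6 cm/s in an ADME assay for permeability, using PAMPA, with a stated time of 30 min, at pH 7.4 (on this read-out higher numbers stand for higher permeability and lower numbers for lower permeability), and stands lowest of the two numbers measured so far. Its nearest neighbour is compound 1, `COc1ccc(Oc2ccc3c(NCCCNCc4cc(F)ccc4OC)ccnc3c2)cc1`, for which this assay gives 317 10^-6 cm/s, so that the step runs a 14-fold lower number from compound 1 to compound 2 (1.14 log units; beyond the scatter) with 4-fluorobenzyl in place of 4-methoxyphenoxy on an aromatic carbon.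

Compound 3, `COc1ccc(F)cc1CNCCCNc1ccnc2cc(-c3ccccc3)ccc12`, has not yet been measured in this assay. It differs from compound 2 in one place: phenyl in place of 4-fluorobenzyl on an aromatic carbon.

Among the compounds with values here, the only measured step, from compound 1 to compound 2, exchanges a different group at the same place and is large, but neither of its two groups is the phenyl that enters here, so no measured step bears directly on the change from compound 2 to compound 3. On the numbers available, compound 3 is expected to stay near compound 2, with a step of a 1.3-fold higher number from compound 2 to compound 3 (0.12 log units; within the scatter) that may well lie within the scatter. The estimate for compound 3 in this assay is therefore 30 10^-6 cm/s, with a range from 10 10^-6 cm/s to 90 10^-6 cm/s.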

Compound 3, apparent permeability: 237 10^-6 cm/s
Compound 3: the middle estimate sits 7.9-fold (0.90 log units) below what was measured, outside the stated range (above it).
By their numbers in this assay, from the lowest: compound 2; then compounds 3 and 1 (each within the scatter of the next).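

At this aromatic carbon, the read-out in this assay turns out to be highly sensitive to the exchange of 4-fluorobenzyl for phenyl, with a 10-fold higher number from compound 2 to compound 3 (1.01 log units; beyond the scatter) on a change that leaves one six-membered aromatic ring of carbon in place at that position. Taking 4-methoxyphenoxy away is therefore not enough on its own to produce the low number of compound 2, since phenyl in its place gives a 1.3-fold lower number from compound 1 to compound 3 (0.13 log units; within the scatter) and so leaves these two compounds level within the scatter; among the three compounds, 4-fluorobenzyl alone stands apart. Nothing measured for these compounds accounts for this difference.

The compounds shown leave open whether the low number goes with the carbon link of 4-fluorobenzyl or with its fluorine, a question that a plain benzyl and a 4-fluorophenyl group at the same carbon would separate. They also leave open how the read-out would respond to a group of a different kind at this carbon, such as an amine or a carboxylic acid.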